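A methoxy regiochemistry step in a maximal electroshock series

The compounds below may be only part of what the source reports. "The series", "measured", "known", "first", "only" and "open" are said of these compounds alone.

Three compounds of a shared core have numbers in a functional assay on the whole organism (strain albino) with Mus musculus as the target, in the maximal electroshock model, with a stated time of 0.5 h; a higher number here means that more compound is needed for the effect, a lower number that less compound is needed. Compound 1 `COc1ccc(Nc2nnc(Nc3nc(-c4ccc(Cl)cc4)cs3)s2)cc1` gives 100 mg/kg. Compound 2 `Cc1ccccc1Nc1nnc(Nc2nc(-c3ccccc3)cs2)s1` gives 300 mg/kg. Compound 3 `COc1ccccc1Nc1nnc(Nc2nc(-c3ccccc3)cs2)s1` gives 100 mg/kg. Among the compounds with values here, on these numbers compound 3 is level with compound 1 at the digits printed, and the two together stand at the lowest number of the three; the only step beyond the scatter is a 3.0-fold lower number from compound 2 to compound 3 (0.48 log units; beyond the scatter), the exchange of a methyl for a methoxy on an aromatic carbon.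

The next compound, compound 4 `COc1ccc(Nc2nnc(Nc3nc(-c4ccccc4)cs3)s2)cc1`, is not yet measured in this assay. It differs from compound 3 by 4-methoxyphenyl in place of 2-methoxyphenyl on a nitrogen on an aromatic ring, so the same atoms are joined differently.

Within the data shown here, no measured step moves a methoxy around the same ring, so the change has no direct precedent. What the numbers do show is that compound 1, which carries the 4-methoxyphenyl, gives 100 mg/kg, the same figure as compound 3 with the 2-methoxyphenyl. On that ground compound 4 is expected to sit close to compound 3, with a step of no change at the digits printed from compound 3 to compound 4 (within the scatter) that stays within the scatter. The estimate for compound 4 is therefore 100 mg/kg, with a range from 50 mg/kg to 300 mg/kg.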

Compound 4, minimum effective dose: 100 mg/kg
Compound 4: middle estimate and measured number agree at the digits printed; measured number inside the range.
By their numbers in this assay, from the lowest: compounds 1, 3 and 4 (each within the scatter of the next); then compound 2.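

Moving the methoxy on the ring carried by the nitrogen, with 4-methoxyphenyl in place of 2-methoxyphenyl, gives in this assay no change at the digits printed from compound 3 to compound 4 (within the scatter) and so separates neither arrangement from the other at this place. The exchange of 2-methylphenyl for 4-methoxyphenyl gives a 3.0-fold lower number from compound 2 to compound 4 (0.48 log units; beyond the scatter) and matches in size the earlier methyl-to-methoxy step, so both methoxyphenyl arrangements stand apart from the 2-methylphenyl compound. Within the data shown here, the first reading on the other aryl group, no change at the digits printed from compound 1 to compound 4 (within the scatter) with hydrogen in place of chloro on an aromatic carbon, shows that this exchange also leaves the number within the scatter, although no measurement is at hand to explain either flat step.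

The compounds shown leave open what a plain phenyl on that nitrogen would give, and so how much of the difference from compound 2 belongs to the methoxy rather than to the loss of the methyl. They also leave open whether a group of another kind on either ring, such as an amine, a carboxylic acid or a longer chain, would move the number as chloro and hydrogen did not.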